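The compounds below may be only part of what the source reports. "The series", "measured", "known", "first", "only" and "open" are said of these compounds alone.

Measured in a functional assay on A549 cells (Homo sapiens) for antiproliferative activity, read by MTT assay; a higher number here means a weaker inhibitor, a lower number a stronger inhibitor:
- compound 1 `Cc1c(-n2cc(COc3ccc(/C=C/C(=O)c4cc5c(cc4O)OC(C)(C)CC5)cc3)nn2)cccc1[N+](=O)[O-]`: 65900 nM
- compound 2 `CCc1ccccc1-n1cc(COc2ccc(/C=C/C(=O)c3cc4c(cc3O)OC(C)(C)CC4)cc2)nn1`: 137000 nM
- compound 3 `Cc1c(-n2cc(COc3ccc(/C=C/C(=O)c4ccc5c(c4O)CCC(C)(C)O5)cc3)nn2)cccc1[N+](=O)[O-]`: "not active" (no number reported)

Compound 3 is reported as "not active" (no number reported), so it offers no number to start from. Compound 4 `CCCCCCCCn1cc(COc2ccc(/C=C/C(=O)c3ccc4c(c3O)CCC(C)(C)O4)cc2)nn1` keeps the core of compound 3 but carries octyl in place of 2-methyl-3-nitrophenyl on an aromatic nitrogen. Going by the values given here, the only measured step at this place is a 2.1-fold higher number from compound 1 to compound 2 (0.32 log units; beyond the scatter). That step is modest, sits on the core of compound 1, and does not introduce octyl, so it sets no firm size or direction here. In this assay, a number near compound 1 at 65900 nM is expected, although another result without a number remains possible. For compound 4 the estimated value is 80000 nM, with an expected range of 25000 nM to 200000 nM.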

Compound 4, half-maximal inhibitory concentration: "not active" (no number reported)
No number was reported for compound 4, so the estimate cannot be set against anything.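

Compound 3 and compound 4 are both reported as "not active" in this assay, without a number, so no step can be read between them. Going by these compounds, how octyl compares with 2-methyl-3-nitrophenyl on this core stays open. No evidence bears on this result.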